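The compounds below may be only part of what the source reports. "The series", "measured", "known", "first", "only" and "open" are said of these compounds alone.

Compound 2 `COc1ccc([N+](=O)[O-])cc1CSc1nc2cc(NC(=O)NC(C)(C)C)ccc2n1Cc1cccnc1` carries a (pyridin-3-yl)methyl group on a ring nitrogen of the shared core; in an assay on isolated protein for inhibition of Gonadotropin-releasing hormone receptor (Rattus norvegicus) (a lower number here means a stronger inhibitor, a higher number a weaker inhibitor), compound 2 gives 150 nM, the lowest of the two numbers recorded. Its nearest neighbour is compound 1 `COCCn1c(SCc2cc([N+](=O)[O-])ccc2OC)nc2cc(NC(=O)NC(C)(C)C)ccc21`, which in this assay gives 280 nM; the step of a 1.9-fold lower number from compound 1 to compound 2 (0.27 log units; within the scatter) stays within the scatter. Compound 3 `COc1ccc([N+](=O)[O-])cc1CSc1nc2cc(NC(=O)NC(C)(C)C)ccc2n1C(C)C` differs from compound 2 only at that nitrogen: isopropyl in place of (pyridin-3-yl)methyl on an aromatic nitrogen. Going by the values given here, the one measured step that bears on this position, a 1.9-fold lower number from compound 1 to compound 2 (0.27 log units; within the scatter), exchanged one nitrogen substituent for another without moving the number beyond the scatter, so a further exchange at the same nitrogen is expected to leave the number close to where compound 2 stands, with only a small drift possible. For compound 3 the expected step is a 1.7-fold higher number from compound 2 to compound 3 (0.22 log units; within the scatter). Compound 3 is therefore estimated at 250 nM, with a likely range from 100 nM to 700 nM.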

Compound 3, half-maximal inhibitory concentration: 62 nM
For compound 3 the middle estimate is 4.0-fold (0.61 log units) above the measured one, and the stated range ends above it.
By their numbers in this assay, from the lowest: compound 3; then compounds 2 and 1 (each within the scatter of the next).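

In this assay, the substituent on this aromatic nitrogen now moves the number beyond the scatter: isopropyl in place of (pyridin-3-yl)methyl gives a 2.4-fold lower number from compound 2 to compound 3 (0.38 log units; beyond the scatter) and isopropyl in place of 2-methoxyethyl gives a 4.5-fold lower number from compound 1 to compound 3 (0.65 log units; beyond the scatter) whereas the earlier exchange between those two larger groups did not. Both steps are modest, but they show that this position is not indifferent to its substituent and that a group of 3 heavy atoms, with no ring and no hydrogen-bond acceptor, is accommodated here. No available evidence bears on the reason for this difference.

Going by these compounds, it remains open whether the lower number follows from losing the ring, which a cyclopentyl group could test, or from losing the pyridine nitrogen, which a benzyl group could test. A tert-butyl group or an ethyl chain would show how far the trend extends among simple alkyl groups.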